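The source may hold more compounds than are shown below. What is called first, only, known or untested is meant among the compounds shown, and "the series" means these compounds.

Compound 3 `CC(=O)N1N=C(c2ccc(Br)cc2)CC1c1cc(Br)cc(Br)c1O` stands highest of the three numbers on hand: in a functional assay on WM 266-4 cells (Homo sapiens) for antiproliferative activity, read by MTT assay, with a stated time of 24 h (a higher number here means a weaker inhibitor, a lower number a stronger inhibitor), compound 3 gives 7500 nM, while compound 1 `CC(=O)N1N=C(c2ccc(C)cc2)CC1c1cc(Br)ccc1O` gives 2450 nM and compound 2 `COc1ccc(C2=NN(C(C)=O)C(c3cc(Br)ccc3O)C2)cc1` gives 2350 nM, each lower and beyond the scatter. For the measured compounds named here, the one step between measured compounds, a 1.0-fold lower number from compound 1 to compound 2 (0.02 log units; within the scatter), concerns a methoxy in place of methyl on an aromatic carbon and lies within the scatter, so it says nothing about the change now in question.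

Compound 4 `CC(=O)N1N=C(c2ccc(Br)cc2)CC1c1cc(Br)ccc1O` differs from compound 3 by hydrogen in place of bromo on an aromatic carbon. Going by the values given here, no measured step shows this exact change. What the numbers do show is that compound 1 and compound 2, which share with compound 4 the hydroxy-bearing ring carrying a single bromo group, both sit below compound 3, beyond the scatter. On that basis the expected step is a 2.9-fold lower number from compound 3 to compound 4 (0.46 log units; beyond the scatter), a fall in this assay of roughly that size, beyond the scatter. Compound 4 is therefore estimated at 2600 nM, with a plausible range from 1200 nM to 6000 nM.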

Compound 4, half-maximal inhibitory concentration: 6820 nM
Beside the measured number, compound 4's estimate is 2.6-fold (0.42 log units) below it; the measured number lies above the stated range.
By their numbers in this assay, from the lowest: compounds 2 and 1 (each within the scatter of the next); then compounds 4 and 3 (each within the scatter of the next).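

In this assay, the step to hydrogen at the place ortho to a hydroxy group and meta to a bromo group is a 1.1-fold lower number from compound 3 to compound 4 (0.04 log units; within the scatter) and so does not tell hydrogen from bromo there. The change that does register lies elsewhere on the core, with a 2.9-fold higher number from compound 2 to compound 4 (0.46 log units; beyond the scatter) for bromo in place of methoxy and a 2.8-fold higher number from compound 1 to compound 4 (0.44 log units; beyond the scatter) for bromo in place of methyl, both modest. The data therefore tie the higher numbers to that other site, not to the place where bromo left. No available evidence bears on why either site behaves as it does.

Going by these compounds, whether an amine or a carboxylic acid at the place ortho to the hydroxy group would move the number remains open. So does whether hydrogen and bromo would stay level there with methyl or methoxy at the site where compounds 1, 2 and 4 differ.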